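The compounds below may be only part of what the source reports. "The series", "measured", "known", "first", "only" and "open" are said of these compounds alone.

Working notes on the aminopyridine carboxamide series.

Compound 1 `CNC(=O)c1cccnc1NCCCN1CCN(c2ccccc2OC)CC1` and compound 2 `CN(C)C(=O)c1cccnc1NCCCN1CCN(c2ccccc2)CC1` are the two members with numbers in hand. In a functional assay on aorta for antagonist activity at Alpha-1D adrenergic receptor (Rattus norvegicus) (a lower number here means tighter binding, a higher number weaker binding), compound 1 gives 3.16 nM. In this assay compound 2 gives 15.9 nM, the higher of the two numbers, and the gap to compound 1 lies beyond the scatter. The two compounds differ in more than one place, so no single step can be read from them; only the two values themselves are on record.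

Compound 3 `CN(C)C(=O)c1cccnc1NCCCN1CCN(c2ccccc2-c2ncco2)CC1` is not yet measured. It differs from compound 2 in one way: 1,3-oxazol-2-yl in place of hydrogen on an aromatic carbon. The group sits on an aromatic carbon of the six-membered carbon ring, ortho to a large group.

Compound 1, which also carries a group on that ring, reached 3.16 nM, and compound 2 without such a group stands at 15.9 nM. On this basis a step toward a lower number is expected for compound 3, estimated as a 2.5-fold lower number from compound 2 to compound 3 (0.40 log units; beyond the scatter), though it may fall within the scatter. For compound 3 the expected value in this assay is 6.3 nM, with a range from 2 nM to 20 nM.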

Compound 3, dissociation constant: 25.1 nM
For compound 3 the middle estimate is 4.0-fold (0.60 log units) below the measured one, and the stated range ends below it.
By their numbers in this assay, from the lowest: compound 1; then compounds 2 and 3 (each within the scatter of the next).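

In this assay, among these compounds, 1,3-oxazol-2-yl in place of hydrogen on an aromatic carbon gives a 1.6-fold higher number from compound 2 to compound 3 (0.20 log units; within the scatter), which is the only single-place comparison in hand. At this place on the six-membered aromatic ring of carbon only, ortho to a large group, a group of 5 heavy atoms can therefore stand in for hydrogen with no change that the scatter allows to be read, something the two earlier compounds, which differ in more than one place, could not show. No measurement at hand bears on the reason for this outcome.

On these data alone, it remains open whether a fluorine atom, a chlorine atom, a primary amine or a phenyl group at this place would give a step beyond the scatter. Also open, as far as these compounds go, is whether 1,3-oxazol-2-yl would give a similar step on the core of compound 1, where the amide carries a single methyl group rather than two.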